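The source may report more compounds than this note shows. Statements on the series, on what has been measured and on what is new or still open speak of the compounds shown alone.

Compound 1 `C=C(C)[C@@H]1CC=C(Cn2cc(COc3ccc(C4NC(=O)NC(C)=C4C(=O)OCC)cc3OC)nn2)CC1` and compound 2 `C=C(C)[C@@H]1CC=C(Cn2cc(COc3ccc(C4NC(=O)NC(C)=C4C(C)=O)cc3)nn2)CC1` share a core and differ in two places at once. In a functional assay on HT-29 cells (Homo sapiens) for inhibition, read by sulforhodamine B assay, with a stated time of 48 h (a lower number here means a stronger inhibitor of growth, a higher number a weaker inhibitor of growth), compound 1 reaches only a limit of the assay, > 100000 nM. In this assay, going by the values given here, compound 2 gives 62600 nM, the only number among the two values shown. The value of compound 1 is a limit (the limit of > 100000 nM in this assay, at which 1 of the 2 values shown sits). Compound 3 `C=C(C)[C@@H]1CC=C(Cn2cc(COc3ccc(C4NC(=O)NC(C)=C4C(C)=O)cc3OC)nn2)CC1` is made from compound 2 by one change, (methoxy in place of hydrogen on an aromatic carbon). The same methoxy is present in compound 1, whose value is a limit, so the expected step from compound 2 to compound 3 is toward weaker growth inhibition, estimated at a 1.4-fold higher number from compound 2 to compound 3 (0.16 log units; within the scatter). Compound 3 is therefore expected near 90000 nM, within 40000 nM to 200000 nM.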

Compound 3, concentration for total growth inhibition: 95000 nM
Estimate against measurement, compound 3: 1.1-fold (0.02 log units) below; the range from low to high includes it.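

Methoxy in place of hydrogen on this aromatic carbon now has a measured size in this assay: a 1.5-fold higher number from compound 2 to compound 3 (0.18 log units; within the scatter), so this change cannot be told apart from the scatter of repeated measurements. Methyl in place of ethoxy on the carbonyl carbon gives an at least 1.0-fold lower number from compound 1 to compound 3 (0.02 log units; that floor lies within the scatter), which is only a floor. Compound 1 stands at a limit of the assay, so that step has no true size: the limit of > 100000 nM in this assay, at which 1 of the 3 values shown sits.

On these data alone, it remains open whether a hydroxyl, an amine or a longer chain such as propoxy on this aromatic carbon would give a step beyond the scatter.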